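Swapping Methyl for Chloro in a Sigma-1 Ligand

This account rests on a few compounds, and the source may have more. Where it says the series, first, only, none or still open, it means among the compounds named here.

Of the compounds shown here, two have been measured in an assay for displacement of a labelled ligand from Sigma non-opioid intracellular receptor 1 (Cavia porcellus); on this read-out lower numbers stand for stronger inhibition and higher numbers for weaker inhibition. Compound 1, `COC(=O)C1(c2ccc(C)cc2)CC1CN1CCC(Cc2ccccc2)CC1`, gives 0.97 nM in this assay. Compound 2, `COC(=O)C1(c2ccc(Cl)cc2)CC1CN1CCN(c2ncccn2)CC1`, gives 350 nM in this assay. Compound 1 thus has the lower of the two numbers, and its gap to compound 2 lies far beyond the usual scatter of repeated measurements. Compound 2 differs from compound 1 in more than one part of the molecule, so its number alone says nothing about any single change. The unmeasured compound 3, `COC(=O)C1(c2ccc(Cl)cc2)CC1CN1CCC(Cc2ccccc2)CC1`, differs from compound 1 in one place: chloro in place of methyl on an aromatic carbon. Going by the values given here, no measured pair shows this change, so no step can be read from the data. The expected step is a 1.2-fold higher number from compound 1 to compound 3 (0.09 log units; within the scatter), estimated to lie within the scatter. The estimate for compound 3 is 1.2 nM, expected to fall between 0.4 nM and 4 nM.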

Compound 3, inhibition constant: 0.82 nM
Compound 3: middle estimate off by 1.5-fold (0.17 log units), on the high side; the range from low to high includes it.
By their numbers in this assay, from the lowest: compounds 3 and 1 (each within the scatter of the next); then compound 2.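

The swap of methyl for chloro can now be read on its own, without any other part of the molecule changing. In this assay there is a 1.2-fold lower number from compound 1 to compound 3 (0.07 log units; within the scatter) and this lies within the usual scatter, so 4-methylphenyl and 4-chlorophenyl cannot be told apart on this core. The low number of compound 1 therefore does not depend on methyl specifically, as chloro serves equally well at this position, though no measurement shown explains why the two groups match.

On these data alone, only these two small groups have been compared here, so it remains open whether a larger or different group at this position, such as an amine, a carboxylic acid or a longer alkyl chain, would keep the number this low. As far as these compounds go, it is also open whether the same swap would make as little difference with the other half of the molecule changed.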